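Predicting a Methoxy Analogue from Three Measured Compounds

The source may hold more compounds than are shown below. What is called first, only, known or untested is meant among the compounds shown, and "the series" means these compounds.

Compound 1 `Cc1ccccc1NC(=S)N1CCc2c(sc(NC(=O)c3ccccc3Cl)c2C(N)=O)C1` is the starting point. In a functional assay on MKN-74 cells (Homo sapiens) for antiproliferative activity, with a stated time of 24 h (on this read-out higher numbers stand for weaker inhibition and lower numbers for stronger inhibition), compound 1 gives 11700 nM. Compound 2 `COc1ccccc1NC(=S)N1CCc2c(sc(NC(=O)c3ccccc3Cl)c2C(N)=O)C1` differs from it by methoxy in place of methyl on an aromatic carbon, and in this assay compound 2 gives 35200 nM, which is a 3.0-fold higher number from compound 1 to compound 2 (0.48 log units; beyond the scatter). Compound 3 `Cc1ccccc1NC(=S)N1CCc2c(sc(NC(=O)c3ccccc3C(F)(F)F)c2C(N)=O)C1` changes a different part of the molecule, and in this assay compound 3 gives 47400 nM, which is a 4.1-fold higher number from compound 1 to compound 3 (0.61 log units; beyond the scatter). Compound 4 `COc1ccccc1NC(=S)N1CCc2c(sc(NC(=O)c3ccccc3C(F)(F)F)c2C(N)=O)C1` is unmeasured. It differs from compound 3 by methoxy in place of methyl on an aromatic carbon, the same change that links compound 1 to compound 2, at a place described in the same words. The cores of the two pairs differ by trifluoromethyl in place of chloro on an aromatic carbon. In this assay the expected step is a 2.5-fold higher number from compound 3 to compound 4 (0.40 log units; beyond the scatter). Within the data shown here, this rests on a 3.0-fold higher number from compound 1 to compound 2 (0.48 log units; beyond the scatter), the one measured instance of the change. Compound 4 is therefore estimated at 120000 nM, expected between 50000 nM and 300000 nM.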

Compound 4, half-maximal inhibitory concentration: 34500 nM
Estimate against measurement, compound 4: 3.5-fold (0.54 log units) above; the whole stated range lies above it.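

In this assay, methoxy in place of methyl gives a 1.4-fold lower number from compound 3 to compound 4 (0.14 log units; within the scatter), so the step seen on the core of compound 1 did not carry over to the core of compound 3: the same change on two cores in this assay, a 3.0-fold higher number (0.48 log units; beyond the scatter) from compound 1 to compound 2 and a 1.4-fold lower number (0.14 log units; within the scatter) from compound 3 to compound 4, 4.1-fold (0.62 log units) apart, beyond the scatter of two such steps

Read the other way, trifluoromethyl in place of chloro gives a 1.0-fold lower number from compound 2 to compound 4 (0.01 log units; within the scatter), and this step also differs from its earlier counterpart: the same change on two cores in this assay, a 4.1-fold higher number (0.61 log units; beyond the scatter) from compound 1 to compound 3 and a 1.0-fold lower number (0.01 log units; within the scatter) from compound 2 to compound 4, 4.1-fold (0.62 log units) apart, beyond the scatter of two such steps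

So, in these four compounds, the result of each change depends on the group present at the other place, but one pair per core cannot show why, or predict what happens on other cores.

Going by these compounds, it remains open how an ethoxy or hydroxy group on that aromatic carbon would behave. The same question applies to a bromo or nitrile group in place of chloro.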